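This account rests on a few compounds, and the source may have more. Where it says the series, first, only, none or still open, it means among the compounds named here.

Compound 1 `CCOc1cc(NC(=O)C2(NC(=O)c3ccc4c(C5CCCC5)c(-c5ncc(Cl)cn5)n(C)c4c3)CCC2)ccc1/C=C/C(=O)OCC(N)=O`: 200000 ug/mL
Compound 2 `CCOc1cc(NC(=O)C2(NC(=O)c3ccc4c(C5CCCC5)c(-c5ncc(Cl)cn5)n(C)c4c3)CCC2)ccc1/C=C/C(=O)OCC(=O)N1CCCC1`: 200000 ug/mL

In an ADME assay for solubility (on this read-out higher numbers stand for higher solubility and lower numbers for lower solubility), compound 2 gives 200000 ug/mL, level with compound 1 at the digits shown, its nearest neighbour. Compound 3 `CCOc1cc(NC(=O)C2(NC(=O)c3ccc4c(C5CCCC5)c(-c5ncc(Cl)cn5)n(C)c4c3)CCC2)ccc1/C=C/C(=O)OCC(=O)N1CCOCC1` differs from compound 2 by morpholin-4-yl in place of pyrrolidin-1-yl on a carbonyl carbon. Within the data shown here, the one measured step that bears on this, no change at the digits printed from compound 1 to compound 2 (within the scatter), also changed the group on that carbonyl carbon and brought no change beyond the scatter. In this assay the expected step is therefore no change at the digits printed from compound 2 to compound 3 (within the scatter), none beyond the scatter. Compound 3 is estimated at 200000 ug/mL, in a range from 100000 ug/mL to 400000 ug/mL.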

Compound 3, solubility: < 15000 ug/mL
Compound 3 ended at the assay's limit; the forecaster's own chance of this, stated with the estimate: 20%; middle value at least 13-fold (1.12 log units) away from the limit.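

In this assay, the group on this carbonyl carbon proves able to move the read-out: morpholin-4-yl in place of pyrrolidin-1-yl gives an at least 13-fold lower number from compound 2 to compound 3 (1.12 log units; beyond the scatter), and morpholin-4-yl in place of amino gives an at least 13-fold lower number from compound 1 to compound 3 (1.12 log units; beyond the scatter). The earlier pair had not shown this, since amino and pyrrolidin-1-yl stood level at this position. Compound 3 sits at a limit of the assay, not at a number: the limit of < 15000 ug/mL in this assay, at which 1 of the 3 values shown sits.

The compounds shown leave open how far compound 3 lies past that limit. They also leave open whether the ring oxygen or the six-membered ring goes with the step, which piperidin-1-yl on the same carbonyl carbon could separate.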